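The source may report more compounds than this note shows. Statements on the series, on what has been measured and on what is new or still open speak of the compounds shown alone.

Of the compounds shown here, three of one shared core have been measured in a functional assay on LOX IMVI cells (Homo sapiens) for inhibition, read by sulforhodamine B assay, with a stated time of 48 h; a higher number here means a weaker inhibitor of growth, a lower number a stronger inhibitor of growth. Compound 1 `COc1ccc2[nH]c(-c3ccccc3)c(C=C(C#N)C#N)c2c1` gives 4900 nM. Compound 2 `COc1ccc(-c2[nH]c3ccc(OC)cc3c2/C=C(\C#N)S(=O)(=O)c2ccccc2)cc1` gives 1200 nM. Compound 3 `CC(=O)/C(=C\c1c(-c2ccccc2)[nH]c2ccccc12)S(=O)(=O)c1ccccc1` gives 1400 nM. Among these three numbers compound 3 holds the second highest; its nearest neighbour is compound 2, whose number is lower by an amount that falls within the usual scatter of such measurements, while compound 1 stands furthest away, with a number higher by a margin that goes beyond that scatter.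

The step under consideration leads from compound 3 to compound 4 `N#C/C(=C\c1c(-c2ccccc2)[nH]c2ccccc12)S(=O)(=O)c1ccccc1`, which has not yet been measured. The change is a single one: cyano in place of acetyl on a double-bonded chain carbon bound to a double-bonded chain carbon and a sulfonyl sulfur. Compound 2 also carries a cyano on that chain carbon next to the sulfonyl, together with a sulfonyl of the same kind, but it differs from compound 3 in more than one place, so its value and that of compound 3 can only be compared as they stand, and they lie within the scatter of each other.

On that basis the expected step in this assay from compound 3 to compound 4 is a 1.1-fold lower number from compound 3 to compound 4 (0.03 log units; within the scatter), in either direction none beyond the scatter. Compound 4 is therefore estimated at 1300 nM, within a range of 500 nM to 3500 nM.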

Compound 4, concentration for 50% growth inhibition: 4600 nM
Compound 4: the middle estimate sits 3.5-fold (0.55 log units) below what was measured; measured number outside the range, above it.
By their numbers in this assay, from the lowest: compounds 2 and 3 (each within the scatter of the next); then compounds 4 and 1 (each within the scatter of the next).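

In this assay, the group on the double-bonded chain carbon bound to a double-bonded chain carbon and a sulfonyl sulfur clearly affects growth inhibition: cyano in place of acetyl gives a 3.3-fold higher number from compound 3 to compound 4 (0.52 log units; beyond the scatter), a step beyond the usual scatter. Among the compounds shown here, this is the first reading of a single change at this position, with the rest of the structure held constant, and it shows that acetyl gives the stronger inhibitor of this pair. Compound 2 also carries cyano on that chain carbon, but it differs from compound 3 in more than one place, so the closeness of their values could not reveal this effect, and no measurement here explains the step.

As far as these compounds go, the comparison covers only acetyl and cyano, so it remains open whether a longer ketone chain, an ester or an amide on this carbon would behave more like acetyl or more like cyano. From the compounds shown here alone, it also remains open whether the same change would give a step of similar size on a core carrying methoxy groups, as compound 2 does.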